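Methoxy for Chloro on an Aromatic Carbon of Compound 1

A few compounds are considered here, and "the series" means these few. Any claim that something is new, unique, unknown or untested is made for them only; others in the source may bear on it.

Measured compounds:
compound 1 `COc1c(/C=C2/C(=O)Nc3ccc(Cl)cc32)c2ccccc2n1-c1ccccc1` gives 4270 nM
compound 2 `COc1cc2c(cc1C)NC(=O)/C2=C/c1c(Cl)n(Cc2cc(OC)c(OC)c(OC)c2)c2cc(C)c(OC)cc12` gives 10000 nM
compound 3 `O=C1/C(=C/c2c(Cl)[nH]c3ccccc23)c2ccccc2N1Cc1ccccc1` gives 4170 nM

Of the compounds shown here, three have been measured in a functional assay on cells (Cancer cell lines, Homo sapiens) for cytotoxicity, with a stated time of 48 h; on this read-out higher numbers stand for weaker inhibition of growth and lower numbers for stronger inhibition of growth. Compound 1 stands second highest of the three numbers. Its nearest neighbour is compound 3, whose value of 4170 nM lies within the usual scatter of the value of compound 1, so no order can be set between these two. The furthest is compound 2, whose value of 10000 nM lies beyond the scatter above the value of compound 1.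

Compound 4 `COc1ccc2c(c1)/C(=C\c1c(OC)n(-c3ccccc3)c3ccccc13)C(=O)N2` has not yet been measured in this assay. It differs from compound 1 in one place: methoxy in place of chloro on an aromatic carbon. The change sits on an aromatic carbon of a six-membered aromatic ring of carbon only, part of a fused or bridged system of two rings, meta to a fused ring and para to a fused ring.

Within the data shown here, no measured pair in this set shows what such a change does. The three measured values all sit in a narrow band, and the change is a small one, so the step from compound 1 to compound 4 is expected to be small, a 1.2-fold higher number from compound 1 to compound 4 (0.07 log units; within the scatter), and may well lie within the scatter. Compound 4 is therefore estimated at 5000 nM, with a range from 2000 nM to 15000 nM.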

Compound 4, concentration for 50% growth inhibition: 630 nM
The estimate for compound 4 lay 7.9-fold (0.90 log units) above the measured number; measured number outside the range, below it.
By their numbers in this assay, from the lowest: compound 4; then compounds 3 and 1 (each within the scatter of the next); then compound 2.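

In this assay, among these compounds, the exchange of chloro for methoxy on this aromatic carbon, meta to a fused ring and para to a fused ring, gives a 6.8-fold lower number from compound 1 to compound 4 (0.83 log units; beyond the scatter) and is the first change in the set that can be read in one place alone. The earlier compounds shown here differ from one another in several places at once, so they could not show that this single position moves the read-out at all; here, a swap of one substituent for another shifts growth inhibition clearly in the stronger direction, with the rest of the core of compound 1 unchanged. Nothing measured here speaks to what lies behind this step, and no cause can be given for it.

What the compounds shown leave open is whether the step follows from the arrival of methoxy or from the departure of chloro, and an amine or an ethoxy group on the same aromatic carbon would help to separate the two. From the compounds shown here alone, it also remains open whether the same exchange would act alike on a core carrying a different group on the ring nitrogen, such as the benzyl group of compound 3.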